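A few compounds are considered here, and "the series" means these few. Any claim that something is new, unique, unknown or untested is made for them only; others in the source may bear on it.

Within the data shown here, compound 3 `Cc1cc(S(=O)(=O)N2C=CNC(=O)[C@H]2CC(=O)N2CCC[C@H](N3CCCC3)C2)c(C)cc1Cl` stands second highest of the three numbers so far in an in vitro functional assay on cells for antagonist activity at B1 bradykinin receptor (Homo sapiens), read by luminescence and calcium flux, with a stated time of 2 h (a lower number here means a stronger inhibitor, a higher number a weaker inhibitor), where compound 3 gives 38 nM. Compound 2 `Cc1cc(S(=O)(=O)N2C=CNC(=O)[C@H]2CC(=O)N2CCC(N(C)C)CC2)c(C)cc1Cl` gives 152 nM in this assay, the step of a 4.0-fold lower number from compound 2 to compound 3 (0.60 log units; beyond the scatter) being modest, while compound 1 `Cc1cc(S(=O)(=O)N2C=CNC(=O)[C@H]2CC(=O)N[C@H]2CCN(C)CC2(C)C)c(C)cc1Cl` gives 0.28 nM, with the step of a 140-fold higher number from compound 1 to compound 3 (2.13 log units; beyond the scatter) being large, as is a 540-fold higher number from compound 1 to compound 2 (2.73 log units; beyond the scatter). Compound 4 `Cc1cc(S(=O)(=O)N2C=CNC(=O)[C@H]2CC(=O)N2C[C@H]3CN(C)C[C@H]3C2)c(C)cc1Cl` arises from compound 3 by the change (a group of 9 heavy atoms (7 carbon, 2 nitrogen; 2 five-membered non-aromatic rings with 1 hetero atom each) in place of a group of 11 heavy atoms (9 carbon, 2 nitrogen; one five-membered non-aromatic ring with 1 hetero atom, one six-membered non-aromatic ring with 1 hetero atom), on a carbonyl carbon). All three measured steps alter the same amine group on that carbonyl carbon, and they ranged from modest to large, so a step beyond the scatter in this assay is possible in either direction, though compound 2 and compound 3 suggest cyclic tertiary amines of this kind land in a similar region. Compound 4 is therefore estimated at 50 nM, within 10 nM to 300 nM, an expected step of a 1.3-fold higher number from compound 3 to compound 4 (0.12 log units; within the scatter).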

Compound 4, half-maximal inhibitory concentration: 136 nM
The estimate for compound 4 lay 2.7-fold (0.43 log units) below the measured number; low and high end bracket the measured number.
By their numbers in this assay, from the lowest: compound 1; then compound 3; then compounds 4 and 2 (each within the scatter of the next).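

In this assay, the group with 2 five-membered non-aromatic rings on the carbonyl carbon gives a 3.6-fold higher number from compound 3 to compound 4 (0.55 log units; beyond the scatter), so it does not match the group it replaces, while the same group gives a 1.1-fold lower number from compound 2 to compound 4 (0.05 log units; within the scatter), leaving these two compounds indistinguishable. Neither group comes near compound 1, as a 490-fold higher number from compound 1 to compound 4 (2.69 log units; beyond the scatter) shows. No data given here account for these differences. Still open, on these data alone, is whether a piperazine or an open-chain diamine on the same carbonyl carbon would narrow that gap. As far as these compounds go, the other stereoisomers of the compound 4 group also remain open.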